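Compound 1: methoxymethyl in place of dimethylcarbamoyl

This account rests on a few compounds, and the source may have more. Where it says the series, first, only, none or still open, it means among the compounds named here.

Compound 1 `Cc1cc(CCC#N)cc(C)c1Oc1cc(Nc2ccc(C#N)cc2)c(N)cc1C(=O)N(C)C`: 72.2%
Compound 2 `CCNC(=O)c1cc(N)c(Nc2ccc(C#N)cc2)cc1Oc1c(C)cc(CCC#N)cc1C`: 85.2%
Compound 3 `Cc1cc(CCC#N)cc(C)c1Oc1cc(Nc2ccc(C#N)cc2)c(N)cc1CNC1CC1`: 78.4%
Compound 4 `COCc1cc(N)c(Nc2ccc(C#N)cc2)cc1Oc1c(C)cc(CCC#N)cc1C`: not yet measured

In an ADME assay on liver for metabolic stability, with Liver microsome (Homo sapiens) as the target, read by LC-MS, using microsomes and NADPH, with a stated time of 30 min, tested at 1 uM (a lower number here means that less of the compound is left, a higher number that more of the compound is left), compound 1 gives 72.2%, which sits clearly under compound 2 and within the scatter of compound 3. Compound 4 carries methoxymethyl in place of dimethylcarbamoyl on an aromatic carbon. The closest measured precedent also removes the dimethylcarbamoyl from that aromatic carbon, with (cyclopropylamino)methyl entering, and it gave a number 6.2 percentage points higher from compound 1 to compound 3 (within the scatter). Ethylamino in place of dimethylamino on a carbonyl carbon gave a number 13 percentage points higher from compound 1 to compound 2 (beyond the scatter), a modest step, but it keeps the carbonyl and so bears less directly. Replacing ethylcarbamoyl with (cyclopropylamino)methyl gave a number 6.8 percentage points lower from compound 2 to compound 3 (within the scatter). On this evidence, a small upward shift that stays within the scatter is expected, though three compounds offer thin support. The expected step is a number 4.8 percentage points higher from compound 1 to compound 4 (within the scatter). The estimated value for compound 4 is 77%, with an expected range from 64% to 89%.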

Compound 4, percent of the compound remaining: 90.8%
Compound 4: middle estimate off by 13.8 percentage points, on the low side; measured number outside the range, above it.
By their numbers in this assay, from the lowest: compounds 1, 3, 2 and 4 (each within the scatter of the next, the first and the last beyond it).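

In this assay, among these compounds, the earlier compounds left open whether any group lacking the carbonyl on this aromatic carbon would move the number beyond the scatter: methoxymethyl in place of dimethylcarbamoyl gives a number 18.6 percentage points higher from compound 1 to compound 4 (beyond the scatter), whereas the (cyclopropylamino)methyl of compound 3 had not. The group entering therefore matters, and methoxy in place of cyclopropylamino on the saturated chain carbon gives a number 12.4 percentage points higher from compound 3 to compound 4 (beyond the scatter), while methoxymethyl in place of ethylcarbamoyl gives only a number 5.6 percentage points higher from compound 2 to compound 4 (within the scatter), so these two groups are not separated in this assay. No measurement shown accounts for these steps.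

On these data alone, how hydroxymethyl, ethoxymethyl or a plain ethyl group on this aromatic carbon would compare remains open. Also open is whether the methoxymethyl step holds when other parts of the shared core change, as all compounds shown differ only at this carbon.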